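The source may report more compounds than this note shows. Statements on the series, on what has been measured and on what is new or still open speak of the compounds shown alone.

Measured compounds in a functional assay on A549 cells (Homo sapiens) for antiproliferative activity, read by MTT assay, with a stated time of 72 h; a lower number here means a stronger inhibitor, a higher number a weaker inhibitor:

compound 1 `CCN(CC)C/C=C/C(=O)Nc1cc2c(N3CCc4ccccc43)ncnc2cc1O[C@@H]1CCOC1` gives 5220 nM
compound 2 `O=C(/C=C/CN1CCCC1)Nc1cc2c(N3CCc4ccccc43)ncnc2cc1O[C@@H]1CCOC1` gives 2230 nM
compound 3 `CCN(CC)C/C=C/C(=O)Nc1cc2c(N3CCCc4ccccc43)ncnc2cc1OC` gives 6410 nM

Compounds 1 and 2 share one core and differ in a single place: pyrrolidin-1-yl in place of diethylamino on a saturated chain carbon bound to a double-bonded chain carbon. In this assay this change gave a 2.3-fold lower number from compound 1 to compound 2 (0.37 log units; beyond the scatter). Compound 3 carries a different core; the difference between the two cores is not broken down here. Among the three measured values, compound 3 stands highest, but its gap to compound 1 is within the scatter, so the two cannot be ordered; only compound 2 stands apart from it, beyond the scatter.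

Compound 4 `COc1cc2ncnc(N3CCCc4ccccc43)c2cc1NC(=O)/C=C/CN1CCCC1` has not yet been measured in this assay. It is the counterpart of compound 2 on the core of compound 3: pyrrolidin-1-yl in place of diethylamino on a saturated chain carbon bound to a double-bonded chain carbon. The place of this change is described in the same words for both pairs, so it is the same change, made a second time on a different core. Going by the values given here, the only evidence for its effect is the single step from compound 1 to compound 2, and whether the second core carries it the same way is unknown.

The working expectation is that compound 4 repeats roughly that step from compound 3, a 2.2-fold lower number from compound 3 to compound 4 (0.34 log units; beyond the scatter), because compound 3 gives 6410 nM and the first pair gave a 2.3-fold lower number from compound 1 to compound 2 (0.37 log units; beyond the scatter). The estimated value for compound 4 in this assay is 2900 nM, with the expected range from 1500 nM to 6000 nM to allow for the change transferring weaker or stronger than once seen.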

Compound 4, half-maximal inhibitory concentration: 2230 nM
Beside the measured number, compound 4's estimate is 1.3-fold (0.11 log units) above it; low and high end bracket the measured number.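

In this assay, pyrrolidin-1-yl in place of diethylamino on a saturated chain carbon bound to a double-bonded chain carbon gave a 2.9-fold lower number from compound 3 to compound 4 (0.46 log units; beyond the scatter), in the same direction as the earlier 2.3-fold lower number from compound 1 to compound 2 (0.37 log units; beyond the scatter). On the compounds shown, the change carries from one core to the other in both direction and size, with no measurable difference between the two steps: the same change on two cores in this assay, a 2.3-fold lower number (0.37 log units; beyond the scatter) from compound 1 to compound 2 and a 2.9-fold lower number (0.46 log units; beyond the scatter) from compound 3 to compound 4, 1.2-fold (0.09 log units) apart, within the scatter of two such steps

Going by these compounds alone, this rests on only one pair on each of two cores in a single cell assay, so it does not show that the step would hold on any further core, nor does it explain why the step occurs or show whether the compounds act in the same way.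

The compounds shown leave open whether the trend extends to other amines at the same place, such as piperidin-1-yl, morpholin-4-yl or dimethylamino, or whether it is particular to the exchange of diethylamino for pyrrolidin-1-yl. Within the data shown here, they also leave open how much of the differences between the cores comes from each part, since the core of compound 1 and the core of compound 3 differ in more than one place, and no pair here isolates any one of those parts.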